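A Methoxy Group Gives Way to Hydrogen

The compounds below may be only part of what the source reports. "The series", "measured", "known", "first", "only" and "open" are said of these compounds alone.

In a toxicity assay on THP-1 cells (Homo sapiens) for inhibition (a lower number here means that less compound is tolerated, a higher number that more compound is tolerated), compound 2 `COc1ccccc1-c1cnc(NC(=O)c2ncc[nH]2)n1C` gives > 50000 nM, which is a limit and not a number. Compound 3 `COc1ccccc1-c1cnc(NC(=O)c2ccc(F)cc2)n1C` gives > 100000 nM, also a limit. Compound 1 `Cn1c(-c2ccccc2)cnc1NC(=O)c1ccccc1` gives > 100000 nM, again a limit. Compound 2 therefore stands without a measured number, and so do the other two compounds shown.

Compound 4 `Cn1c(-c2ccccc2)cnc1NC(=O)c1ncc[nH]1` has not yet been measured. It carries hydrogen in place of methoxy on an aromatic carbon, ortho to a large group (hydrogen in place of methoxy on an aromatic carbon).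

Going by the values given here, only one measured step starts from compound 2, namely a step that the two limits leave unreadable from compound 2 to compound 3. That step puts 4-fluorophenyl in place of 1H-imidazol-2-yl on a carbonyl carbon, so it concerns a different place in the molecule, and it offers no readable size to carry over.

The closer guide is compound 1, which also has hydrogen in place of the methoxy and gives > 100000 nM, a limit. On that basis, no change beyond the usual scatter is expected, and the estimate in this assay is a step that the limit leaves unreadable from compound 2 to compound 4. Compound 4 is estimated at 80000 nM, with an expected range from 40000 nM to 160000 nM.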

Compound 4, half-maximal cytotoxic concentration: > 100000 nM
Compound 4: only a limit was reported; the forecaster's own chance of this, stated with the estimate: 85%; at least 1.2-fold (0.09 log units) between middle value and limit.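

In this assay compound 4 gives > 100000 nM, a limit and not a number. Neither the step from compound 2 to compound 4 nor the step from compound 1 to compound 4 can be read. None of the compounds shown has a measured number, which leaves open whether hydrogen in place of methoxy, or any other change among them, has any effect in this assay.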